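A few compounds are considered here, and "the series" means these few. Any claim that something is new, unique, unknown or untested is made for them only; others in the source may bear on it.

Compound 2 `CN(C(=O)NC(=O)c1ccc(F)c(F)c1)c1nc(C(F)(F)F)c(C(=O)N/N=C/c2cc(C(F)(F)F)cc(C(F)(F)F)c2)s1` carries a 3,4-difluorophenyl on its carbonyl carbon. In a functional assay on HepG2 cells (Homo sapiens) for inhibition, read by MTT assay, with a stated time of 72 h (on this read-out lower numbers stand for stronger inhibition and higher numbers for weaker inhibition), compound 2 gives 5.47 ug/mL, the lowest of the two numbers recorded. Compound 1 `CN(C(=O)NC(=O)c1ccc(Cl)cc1Cl)c1nc(C(F)(F)F)c(C(=O)N/N=C/c2ccc(C(F)(F)F)cc2)s1` follows it; in this assay compound 1 gives 12.4 ug/mL. Compound 3 `CN(C(=O)NC(=O)c1ccc(C(F)(F)F)cc1)c1nc(C(F)(F)F)c(C(=O)N/N=C/c2ccc(C(F)(F)F)cc2)s1` gives > 100 ug/mL in this assay, which is a limit of the assay and not a number. That third value sits at the limit of > 100 ug/mL in this assay, at which 1 of the 3 values shown sits.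

Compound 4 `CN(C(=O)NC(=O)c1ccc(C(F)(F)F)cc1)c1nc(C(F)(F)F)c(C(=O)N/N=C/c2cc(C(F)(F)F)cc(C(F)(F)F)c2)s1` differs from compound 2 in one place: 4-(trifluoromethyl)phenyl in place of 3,4-difluorophenyl on a carbonyl carbon. Within the data shown here, the one measured step with the same entering group is an at least 8.0-fold higher number from compound 1 to compound 3 (0.90 log units; beyond the scatter), and it ends at the limit, so its true size is not known. Since that step brings in the same 4-(trifluoromethyl)phenyl on the carbonyl carbon, a loss of comparable or larger size is expected here, leaving compound 4 with a far higher number and a fair chance that only a limit is reported. The step from compound 2 to compound 4 is estimated at an 11-fold higher number from compound 2 to compound 4 (1.04 log units; beyond the scatter). For compound 4 in this assay the estimate is 60 ug/mL, with a range from 15 ug/mL to 250 ug/mL.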

Compound 4, half-maximal inhibitory concentration: 8.35 ug/mL
Compound 4: the middle estimate sits 7.2-fold (0.86 log units) above what was measured; measured number outside the range, below it.
By their numbers in this assay, from the lowest: compounds 2, 4 and 1 (each within the scatter of the next, the first and the last beyond it). At a limit, above all of these: compound 3.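

On this carbonyl carbon, 4-(trifluoromethyl)phenyl does not have to cost activity: in this assay the change gives a 1.5-fold higher number from compound 2 to compound 4 (0.18 log units; within the scatter). The same entering group gives an at least 8.0-fold higher number from compound 1 to compound 3 (0.90 log units; beyond the scatter), but that pair differs from the new one in the group that leaves and elsewhere in the molecule, so the outcome of this change is not set by the entering group alone. Compound 3 gives a limit and not a number: the limit of > 100 ug/mL in this assay, at which 1 of the 4 values shown sits.

The shown compounds leave open how much of the contrast belongs to the rest of the molecule, since 2,4-dichlorophenyl on this carbonyl carbon appears only with the partner found in compound 1. They also leave open whether a non-aromatic group such as cyclohexyl, or a phenyl carrying an amine or a carboxylic acid, would be tolerated here.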